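A few compounds are considered here, and "the series" means these few. Any claim that something is new, unique, unknown or untested is made for them only; others in the source may bear on it.

Measured so far:
compound 1 `COc1ccc(C(=O)c2cc(C)ccc2OCC(=O)NNC(=O)c2cc3ccccc3oc2=O)cc1` — 43500 nM
compound 2 `Cc1ccc(OCC(=O)NNC(=O)c2cc3ccccc3oc2=O)c(C(=O)c2cccc(Cl)c2)c1` — 68600 nM
compound 3 `Cc1ccc(OCC(=O)NNC(=O)c2cc3ccccc3oc2=O)c(C(=O)c2ccccc2Br)c1` — 10000 nM

Compound 3 gives the lowest number of the three in a functional assay on DLA cells (Mus musculus) for cytotoxicity, read by trypan blue exclusion, with a stated time of 48 h; a higher number here means a weaker inhibitor, a lower number a stronger inhibitor; the steps of a 4.4-fold lower number from compound 1 to compound 3 (0.64 log units; beyond the scatter) and a 6.9-fold lower number from compound 2 to compound 3 (0.84 log units; beyond the scatter) are both beyond the scatter, while a 1.6-fold higher number from compound 1 to compound 2 (0.20 log units; within the scatter) is within it. Compound 4 `Cc1ccc(OCC(=O)NNC(=O)c2cc3ccccc3oc2=O)c(C(=O)c2cccc(Br)c2)c1` differs from compound 3 by 3-bromophenyl in place of 2-bromophenyl on a carbonyl carbon. Among the compounds with values here, no measured step exchanges a 2-bromophenyl for a 3-bromophenyl directly; the step with most bearing is a 6.9-fold lower number from compound 2 to compound 3 (0.84 log units; beyond the scatter), where the 3-chlorophenyl compound gave the higher number, and compound 2 with its 3-chlorophenyl gives 68600 nM. Compound 4 is therefore expected to give a higher number, a step of about a 4.5-fold higher number from compound 3 to compound 4 (0.65 log units; beyond the scatter), roughly reversing that gain. The expected value for compound 4 is 45000 nM, with a range of 15000 nM to 120000 nM.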

Compound 4, half-maximal inhibitory concentration: 71900 nM
Beside the measured number, compound 4's estimate is 1.6-fold (0.20 log units) below it; the measured number falls inside the stated range.
By their numbers in this assay, from the lowest: compound 3; then compounds 1, 2 and 4 (each within the scatter of the next).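

Moving the bromo from 2-bromophenyl to 3-bromophenyl, with the atoms otherwise unchanged, gives a 7.2-fold higher number from compound 3 to compound 4 (0.86 log units; beyond the scatter) in this assay and isolates the placement of the halogen as what matters at this carbonyl carbon. The halogen itself does not separate the pair, with bromo in place of chloro giving a 1.0-fold higher number from compound 2 to compound 4 (0.02 log units; within the scatter) and 3-bromophenyl in place of 4-methoxyphenyl giving a 1.7-fold higher number from compound 1 to compound 4 (0.22 log units; within the scatter), both within the scatter. No measurement here offers a reason for the gap.

From the compounds shown here alone, whether 2-chlorophenyl or 2-methoxyphenyl would match the 2-bromophenyl of compound 3 remains open.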